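Trifluoromethyl on the propanoyl chain of compound 2

The source may hold more compounds than are shown below. What is called first, only, known or untested is meant among the compounds shown, and "the series" means these compounds.

In a functional assay on COR-L23 cells (Homo sapiens) for antiproliferative activity, read by CellTiter-Glo, with a stated time of 4 days (a lower number here means a stronger inhibitor, a higher number a weaker inhibitor), compound 1 `CCC(=O)NCc1ccc(NC(=O)[C@H]2C[C@@H]2c2cccnc2)cc1` reads > 2500 nM, which is a limit of the assay. Going by the values given here, compound 2 `CCC(=O)N[C@@H](C)c1ccc(NC(=O)[C@H]2C[C@@H]2c2cccnc2)cc1` gives 22 nM, the lowest number so far, and compound 3 `CCC(=O)NC(C)(C)c1ccc(NC(=O)[C@H]2C[C@@H]2c2cccnc2)cc1` gives 2310 nM. Methyl in place of hydrogen on a saturated chain carbon bound to an amide-type nitrogen and an aromatic carbon gives a large change, an at least 110-fold lower number from compound 1 to compound 2 (2.05 log units; beyond the scatter). A further large change follows in a 110-fold higher number from compound 2 to compound 3 (2.02 log units; beyond the scatter).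

Compound 4 `C[C@H](NC(=O)CC(F)(F)F)c1ccc(NC(=O)[C@H]2C[C@@H]2c2cccnc2)cc1` differs elsewhere: trifluoromethyl in place of methyl on a saturated chain carbon bound to a carbonyl carbon. This is trifluoromethyl in place of methyl on a saturated chain carbon bound to a carbonyl carbon, or propanoyl to (2,2,2-trifluoroethyl)carbonyl. Among the compounds with values here, compounds 1, 2 and 3 all carry propanoyl, so no measured step tests this change directly, and the two large steps cannot be carried over. Starting from compound 2 at 22 nM, a modest rise in this assay is expected, and the estimated step is a 1.6-fold higher number from compound 2 to compound 4 (0.20 log units; within the scatter). For compound 4 the estimate is 35 nM, with an expected range of 9 nM to 140 nM.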

Compound 4, half-maximal inhibitory concentration: 18 nM
Estimate against measurement, compound 4: 1.9-fold (0.29 log units) above, and the stated range covers the measured number.
By their numbers in this assay, from the lowest: compounds 4 and 2 (each within the scatter of the next); then compound 3. At a limit, above all of these: compound 1.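

Going by these compounds alone, compounds 1, 2 and 3 all carry propanoyl and differ only at the saturated chain carbon bound to an amide-type nitrogen and an aromatic carbon, so this is the first reading at the saturated chain carbon bound to a carbonyl carbon. In this assay, trifluoromethyl in place of methyl gives a 1.2-fold lower number from compound 2 to compound 4 (0.09 log units; within the scatter), so at this position the exchange leaves the number within the scatter, unlike the large steps at the other carbon. Nothing shown here bears on the reason for this result.

As far as these compounds go, whether a longer chain, an amine or a carboxylic acid at this position would also leave the number within the scatter remains open. Also open, from the compounds shown here alone, is whether the same exchange would read alike on the frameworks of compound 1 and compound 3.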